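The compounds below may be only part of what the source reports. "The series", "measured", "known", "first", "only" and "open" are said of these compounds alone.

Measured in a functional assay on V79 cells (Cricetulus griseus) for cytotoxicity, read by colony formation; on this read-out higher numbers stand for weaker inhibition and lower numbers for stronger inhibition:
- compound 1 `NC1CCN(c2c(F)cc3c(=O)c(C(=O)O)cn(C4CC4)c3c2C(F)(F)F)C1`: 300 ug/mL; 300 ug/mL; 300 ug/mL (3 entries)
- compound 2 `CCNCC1CCN(c2c(F)cc3c(=O)c(C(=O)O)cn(C4CC4)c3c2C(F)(F)F)C1`: 120 ug/mL
- compound 3 `NC1CCCN(c2c(F)cc3c(=O)c(C(=O)O)cn(C4CC4)c3c2C(F)(F)F)C1`: > 500 ug/mL, a limit of the assay and not a number

Compound 3 stands at the limit of > 500 ug/mL in this assay, at which 1 of the 3 values shown sits. Going by the values given here, its one measured step is an at least 4.1-fold higher number from compound 2 to compound 3 (0.61 log units; beyond the scatter), a swap of the group on the same aromatic carbon, and it lies beyond the scatter. Compound 4 `CC1CN(c2c(F)cc3c(=O)c(C(=O)O)cn(C4CC4)c3c2C(F)(F)F)CCN1` has the same atoms as compound 3, joined differently: 3-methylpiperazin-1-yl in place of 3-aminopiperidin-1-yl on an aromatic carbon. Among the compounds with values here, no measured compound carries 3-methylpiperazin-1-yl, so that single step is the only guide to how far such a swap can move the number. In this assay a modest move to a lower number is expected, toward compound 1 at 300 ug/mL; 300 ug/mL; 300 ug/mL (3 entries). The expected change is an at least 1.7-fold lower number from compound 3 to compound 4 (0.25 log units; that floor lies within the scatter). For compound 4 the estimate is 280 ug/mL, with an expected range of 110 ug/mL to 700 ug/mL.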

Compound 4, half-maximal inhibitory concentration: 220 ug/mL
Estimate against measurement, compound 4: 1.3-fold (0.10 log units) above, within the range that was stated.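

In this assay the same atoms joined differently, 3-methylpiperazin-1-yl in place of 3-aminopiperidin-1-yl, give an at least 2.2-fold lower number from compound 3 to compound 4 (0.35 log units; beyond the scatter) on this aromatic carbon, so rearranging the ring and its nitrogens is enough to shift the read-out. Compound 3 sits at a limit of the assay and not at a number, so that step gives only a floor: (the limit of > 500 ug/mL in this assay, at which 1 of the 4 values shown sits). Set against 3-((ethylamino)methyl)pyrrolidin-1-yl, the new group gives a 1.8-fold higher number from compound 2 to compound 4 (0.26 log units; within the scatter) and the two are not told apart here. Still open, from the compounds shown here alone, is how a plain piperazin-1-yl, without the methyl group, or a morpholin-4-yl would read at this aromatic carbon.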